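Swapping an amide for a dichloropyridinyl ether: an estimate

A few compounds are considered here, and "the series" means these few. Any claim that something is new, unique, unknown or untested is made for them only; others in the source may bear on it.

Compound 1 `CC(C)NC(=O)c1ccc(-c2onc3ccc(C(=O)O)cc23)cc1`: in an assay for inhibition of inositol hexakisphosphate kinase 2 (Homo sapiens), read by colorimetric assay, coupled enzyme assay and malachite green, with a stated time of 120 min, in the presence of a further agent that is not named here (on this read-out higher numbers stand for weaker inhibition and lower numbers for stronger inhibition), compound 1 gives 350 nM.
Compound 2 `O=C(O)c1ccc2noc(-c3cccc(NC(=O)C4CC4)c3)c2c1`: in this assay compound 2 gives 410 nM.

Compound 2 has the higher of these two numbers, yet compound 1 lies within the usual scatter of it, so the two cannot be told apart on this read-out. Compound 3 `O=C(O)c1ccc2noc(-c3cccc(Oc4ncc(Cl)cc4Cl)c3)c2c1` differs from compound 2 in one place: (3,5-dichloropyridin-2-yl)oxy in place of (cyclopropylcarbonyl)amino on an aromatic carbon. Going by the values given here, no measured pair shows a comparable change, so the size and direction of the step in this assay are unknown; a modest step either way, or none beyond the scatter, is plausible. Compound 3 is therefore expected to give about 500 nM, between 150 nM and 2000 nM. That would mean an expected step of a 1.2-fold higher number from compound 2 to compound 3 (0.09 log units; within the scatter).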

Compound 3, half-maximal inhibitory concentration: 71 nM
For compound 3 the middle estimate is 7.0-fold (0.85 log units) above the measured one; measured number below the stated range.
By their numbers in this assay, from the lowest: compound 3; then compounds 1 and 2 (each within the scatter of the next).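

On this aromatic carbon the group matters in this assay: (3,5-dichloropyridin-2-yl)oxy in place of (cyclopropylcarbonyl)amino gives a 5.8-fold lower number from compound 2 to compound 3 (0.76 log units; beyond the scatter) and so moves the number beyond the scatter. Stronger inhibition is therefore possible here with a group that has no hydrogen-bond donor and a larger count of heavy atoms. Nothing available here bears on why the number falls.

Going by these compounds, whether the step belongs to the ether oxygen, the ring nitrogen or the chlorine atoms stays open. A plain phenoxy group on the same carbon would begin to separate these parts.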